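The compounds below may be only part of what the source reports. "The series", "measured", "known", "first", "only" and "open" are said of these compounds alone.

Three compounds share one core and differ only in what sits on the two aromatic rings. Compound 1 `CC(O)(C(=O)Nc1ccc(S(=O)(=O)c2ccccc2)c(O)c1)C(F)(F)F` gives 430 nM in a functional assay (Cavia porcellus) with sulfonylurea receptors; K-ATP channels (Homo sapiens) as the target; on this read-out lower numbers stand for stronger inhibition and higher numbers for weaker inhibition. Compound 3 `CC(O)(C(=O)Nc1ccc(S(=O)(=O)c2ccccc2)c([N+](=O)[O-])c1)C(F)(F)F` is the same molecule with nitro in place of hydroxy on an aromatic carbon. In this assay, going by the values given here, compound 3 reaches only the limit > 30000 nM, which is a limit of the measurement and not a number; it is the one value that sits at the line (the limit of > 30000 nM in this assay, at which 1 of the 3 values shown sits). The step is therefore an at least 69-fold higher number from compound 1 to compound 3 (1.84 log units; beyond the scatter). Compound 2 `CC(O)(C(=O)Nc1ccc(S(=O)(=O)c2ccccc2O)cc1)C(F)(F)F` gives 3090 nM in this assay, the highest of the two numbers that were actually read, and its nearest neighbour is compound 1 with its lower number.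

Compound 4 `CC(O)(C(=O)Nc1ccc(S(=O)(=O)c2ccc([N+](=O)[O-])cc2)cc1)C(F)(F)F` has not been measured. It differs from compound 2 by 4-nitrophenyl in place of 2-hydroxyphenyl on a sulfonyl sulfur. Among the compounds with values here, the one measured step that bears on it is the nitro-for-hydroxy swap from compound 1 to compound 3, which was large and ran towards weaker inhibition, although there the change sat on a different aromatic carbon. Starting from the already weaker compound 2, a further rise in the number is expected, of the size a 3.9-fold higher number from compound 2 to compound 4 (0.59 log units; beyond the scatter). Compound 4 is therefore estimated at 12000 nM in this assay, within a range from 3000 nM to 30000 nM.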

Compound 4, half-maximal inhibitory concentration: > 30000 nM
Compound 4: no number, only a limit (the forecaster's own chance of this, stated with the estimate: 35%); middle value at least 2.5-fold (0.39 log units) away from the limit.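

In this assay, exchanging 2-hydroxyphenyl for 4-nitrophenyl on a sulfonyl sulfur gives an at least 9.7-fold higher number from compound 2 to compound 4 (0.98 log units; beyond the scatter), so inhibition weakens with a nitro-bearing ring at this place too, whereas the earlier step concerned a nitro group on the other aromatic ring. Compound 4 stands at a limit of the measurement and not at a number, so this step gives only a minimum size: the limit of > 30000 nM in this assay, at which 2 of the 4 values shown sit. The change also replaces the hydroxy group with nitro and alters where the substituent sits on the ring in a single move, so this pair cannot separate the loss of the hydroxy group from the arrival of the nitro group.

The compounds shown leave open whether 4-hydroxyphenyl on the sulfonyl sulfur would stay close to compound 2 at 3090 nM, which would help to divide the effect of the group from that of its place on the ring. They also leave open how this ring would behave carrying an amine, a methoxy group or a carboxylic acid instead of the nitro group.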